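The source may hold more compounds than are shown below. What is called first, only, known or untested is meant among the compounds shown, and "the series" means these compounds.

In an in vivo ADME assay on the whole organism for metabolic stability, with Canis familiaris (Canis lupus familiaris) as the target (on this read-out lower numbers stand for a shorter-lived compound and higher numbers for a longer-lived compound), compound 1 `CC(C)(C)N1CCC(c2cc(-c3ccc(F)cc3Cl)c3ccc(=O)n(-c4c(Cl)cccc4Cl)c3c2)CC1` gives 5.59 h, compound 2 `CC(C)(C)N1CCC(c2cc(-c3ccc(F)cc3F)c3ccc(=O)n(-c4c(Cl)cccc4Cl)c3c2)CC1` gives 19.8 h, and compound 3 `CC(C)(C)N1CCC(c2cc3c(ccc(=O)n3-c3c(Cl)cccc3Cl)c(-c3ccc(F)cc3F)n2)CC1` gives 15.6 h. Compound 3 thus lies within the scatter of compound 2, while compound 1 has the lower number, beyond the scatter. Compound 4 `CC(C)(C)N1CCC(c2cc3c(ccc(=O)n3-c3c(Cl)cccc3Cl)c(-c3ccccc3Cl)n2)CC1` carries 2-chlorophenyl in place of 2,4-difluorophenyl on an aromatic carbon next to the ring nitrogen: 2-chlorophenyl in place of 2,4-difluorophenyl on an aromatic carbon. Among the compounds with values here, the one measured step that bears on this is a 3.5-fold higher number from compound 1 to compound 2 (0.55 log units; beyond the scatter), for fluoro in place of chloro on an aromatic carbon. It was measured on the core of compound 1, and the new change runs the opposite way. A drop of similar size, beyond the scatter, is therefore expected. The expected step is a 3.1-fold lower number from compound 3 to compound 4 (0.49 log units; beyond the scatter). For compound 4 the estimated half-life is 5 h, with an expected range of 2.2 h to 11 h.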

Compound 4, half-life: 5.42 h
Compound 4: the middle estimate sits 1.1-fold (0.04 log units) below what was measured; low and high end bracket the measured number.
By their numbers in this assay, from the lowest: compounds 4 and 1 (each within the scatter of the next); then compounds 3 and 2 (each within the scatter of the next).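

In this assay the move from 2,4-difluorophenyl to 2-chlorophenyl on the aromatic carbon next to the ring nitrogen gives a 2.9-fold lower number from compound 3 to compound 4 (0.46 log units; beyond the scatter) and so shows that the halogen pattern on this aryl group matters on the core of compound 3, not only on the core of compound 1. Within the data shown here, this change removes both fluoro groups and adds a chloro group at once, so the single step cannot assign the drop to any one of them. No measurement offered here explains the drop. On these data alone, whether 2-fluorophenyl or unsubstituted phenyl at this position would keep the longer half-life stays open.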